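Nitro in Place of Fluoro: An Expected Value

The source may hold more compounds than are shown below. What is called first, only, known or untested is meant among the compounds shown, and "the series" means these compounds.

Going by the values given here, compound 1 `O=C(Nc1cccc(-c2oc3cc(-c4ccc(F)cc4)ccc3c(=O)c2O)c1)c1ccc(F)cc1` is the only compound here with a number rather than a limit: in a functional assay on HepG2 cells (Homo sapiens) for antiproliferative activity, read by CCK-8 assay, with a stated time of 72 h (on this read-out lower numbers stand for stronger inhibition and higher numbers for weaker inhibition), compound 1 gives 9280 nM. Compound 2 `O=C(Nc1cccc(-c2oc3cc(-c4ccc(F)cc4)ccc3c(=O)c2O)c1)c1ccc(Br)cc1F` differs only in the group on the carbonyl carbon, 4-bromo-2-fluorophenyl in place of 4-fluorophenyl. For compound 2 this assay reports only a limit, > 100000 nM. Among the compounds with values here, that step, an at least 10-fold higher number from compound 1 to compound 2 (1.03 log units; beyond the scatter), is the one comparison available, and it ends at the limit of > 100000 nM in this assay, at which 1 of the 2 values shown sits. Compound 3 `O=C(Nc1cccc(-c2oc3cc(-c4ccc(F)cc4)ccc3c(=O)c2O)c1)c1ccc([N+](=O)[O-])cc1` alters the same ring in a different way: nitro in place of fluoro on an aromatic carbon. Within the data shown here, no measured step tests a nitro group, so the single large loss seen on the way to compound 2 serves as the only guide, and it points toward loss rather than gain. Compound 3 is therefore expected to show a modestly weaker result, a 1.6-fold higher number from compound 1 to compound 3 (0.21 log units; within the scatter), with wide uncertainty. The estimated value for compound 3 is 15000 nM, between 4000 nM and 60000 nM.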

Compound 3, half-maximal inhibitory concentration: 1860 nM
Estimate against measurement, compound 3: 8.1-fold (0.91 log units) above; the measured number lies below the stated range.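

In this assay, nitro in place of fluoro gives a 5.0-fold lower number from compound 1 to compound 3 (0.70 log units; beyond the scatter), so a change on the aromatic ring attached to the carbonyl can strengthen the result as well as weaken it. The two replacements for 4-fluorophenyl also end far apart, with an at least 53-fold lower number from compound 2 to compound 3 (1.73 log units; beyond the scatter), so the outcome at this place depends strongly on which group it carries. For compound 2 the reported value is a limit and not a number: the limit of > 100000 nM in this assay, at which 1 of the 3 values shown sits.

The compounds shown do not separate the bromo group from the added fluoro in the loss seen with compound 2. They also leave open whether the gain is particular to nitro or would also appear with another group in its place, such as an amine, a nitrile or a carboxylic acid.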